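A few compounds are considered here, and "the series" means these few. Any claim that something is new, unique, unknown or untested is made for them only; others in the source may bear on it.

Compound 1 `Cc1cc2nn(-c3ccccc3)c(N)c2c(=O)[nH]1` and compound 2 `COc1ccc(-c2cc3nn(-c4ccccc4)c(N)c3c(=O)[nH]2)cc1` share a core that has been examined in an assay on isolated protein for inhibition of protein kinase C zeta type (Homo sapiens), read by mobility shift assay, tested at 30 uM; a lower number here means less inhibition, a higher number more inhibition at the concentration tested (going by the name of the read-out). In this assay compound 1 gives -49%, and compound 2 gives 0%. Compound 1 therefore stands lowest of the two numbers, with compound 2 as its nearest neighbour, a step of a number 49 percentage points higher from compound 1 to compound 2 (beyond the scatter). Compound 3 `Cc1[nH]c(=O)c2c(N)n(-c3ccccc3)nc2c1-c1ccccc1` has not yet been measured; it differs from compound 1 by phenyl in place of hydrogen on an aromatic carbon. Among the measured compounds shown here, only one measured step exists to judge this by, and it is the step from compound 1 to compound 2, which was large and upward but placed a different group at a different aromatic carbon, so it bears on compound 3 only loosely. On that basis an upward step of moderate size is expected, a number 34 percentage points higher from compound 1 to compound 3 (beyond the scatter). The estimate for compound 3 in this assay is -15%, expected to fall between -50% and 20%.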

Compound 3, a percentage reported as inhibition, at one concentration (the size of the read-out at that concentration, not a potency): 26%
The estimate for compound 3 lay 41 percentage points below the measured number; the whole stated range lies below it.
By their numbers in this assay, from the lowest: compound 1; then compound 2; then compound 3.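

The aromatic carbon ortho to a methyl group accepts phenyl in place of hydrogen with a large rise in this assay and the change reads as a number 75 percentage points higher from compound 1 to compound 3 (beyond the scatter) in this first look at that position. Among the compounds shown here, the methyl group stays in place here, so replacing it, as the earlier step did at its own carbon, is not the only change on the shared core that raises the number. Nothing measured here accounts for the size of this rise.

The compounds shown leave open whether an amine, a carboxylic acid or a benzyl group on this same carbon would move the number as phenyl does. They also leave open whether 4-methoxyphenyl at this carbon would give a number different from that of phenyl.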